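Replacing the carbamate of compound 3 with a cyclopropyl amide

The source may hold more compounds than are shown below. What is called first, only, known or untested is meant among the compounds shown, and "the series" means these compounds.

In a functional assay on isolated protein for agonist activity at Glucose-dependent insulinotropic receptor (Rattus norvegicus), read by HTRF and cAMP accumulation (on this read-out lower numbers stand for smaller maximal responses and higher numbers for larger maximal responses), compound 1 `CC(C)(C)OC(=O)N1CCC(O[C@H]2CC[C@H](Oc3ccc(S(C)(=O)=O)cc3)CC2)CC1` gives 120% and compound 2 `CC(C)(C)OC(=O)N1CCC(O[C@H]2CC[C@H](Oc3ccc(C#N)cc3)CC2)CC1` gives 106%; the step of a number 14 percentage points lower from compound 1 to compound 2 (beyond the scatter) is the only one measured. Compound 3 `CC1(OC(=O)N2CCC(O[C@H]3CC[C@H](Oc4cnc(S(C)(=O)=O)cn4)CC3)CC2)CC1` gives 123% in this assay, the highest of the three numbers, though its gap to compound 1 lies within the scatter and only its gap to compound 2 lies beyond it. Compound 4 `CS(=O)(=O)c1cnc(O[C@H]2CC[C@H](OC3CCN(C(=O)C4(C(F)(F)F)CC4)CC3)CC2)cn1` differs from compound 3 by 1-(trifluoromethyl)cyclopropyl in place of (1-methylcyclopropyl)oxy on a carbonyl carbon. Within the data shown here, no measured step touches this part of the molecule, so nothing in the data points to a shift in either direction, and the change expected is a number 8 percentage points lower from compound 3 to compound 4 (within the scatter), within the scatter. Compound 4 is therefore estimated at 115% in this assay, with a range from 95% to 135%.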

Compound 4, largest response reached (Emax), in percent of the reference or control that the assay uses: 140%
For compound 4 the middle estimate is 25 percentage points below the measured one, and the stated range ends below it.
By their numbers in this assay, from the lowest: compound 2; then compounds 1 and 3 (each within the scatter of the next); then compound 4.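

In this assay, among these compounds, the substituent on the carbonyl carbon turns out to be a place where the maximal response can move, with a number 17 percentage points higher from compound 3 to compound 4 (beyond the scatter), whereas the only earlier step lay on an aromatic carbon. The (1-methylcyclopropyl)oxy group is therefore not required for a large response at this position. Nothing available explains the gain.

The compounds shown leave open whether the trifluoromethyl group or the loss of the oxygen link carries the step, and a plain 1-methylcyclopropyl group on the same carbonyl would separate the two. On these data alone, whether the step holds with a nitrile in place of the methylsulfonyl group also remains open.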